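Chloropurine benzyl series: amino substitution and cytotoxicity

The compounds below may be only part of what the source reports. "The series", "measured", "known", "first", "only" and "open" are said of these compounds alone.

Measured compounds:
compound 1 `ClCc1ccc(Cn2cnc3c(Cl)ncnc32)cc1`: 57500 nM
compound 2 `Nc1nc(Cl)c2ncn(Cc3ccc(CCl)cc3)c2n1`: 69200 nM
compound 3 `ClCc1ccccc1Cn1cnc2c(Cl)ncnc21`: 20000 nM

Compounds 1 and 3 have the same atoms joined differently; the difference between the two cores is not broken down here. In a functional assay on BT-549 cells (Homo sapiens) for cytotoxicity, read by sulforhodamine B assay, with a stated time of 48 h (on this read-out lower numbers stand for higher toxicity in this test and higher numbers for lower toxicity in this test), compound 3 gives the lowest number of the three, beyond the scatter against compound 1 and against compound 2. The change amino in place of hydrogen on an aromatic carbon gave a 1.2-fold higher number from compound 1 to compound 2 (0.08 log units; within the scatter).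

Compound 4 `Nc1nc(Cl)c2ncn(Cc3ccccc3CCl)c2n1` is not yet measured. It arises from compound 3 by amino in place of hydrogen on an aromatic carbon, the same change as from compound 1 to compound 2. Resting on that earlier step, the expected step is a 1.2-fold higher number from compound 3 to compound 4 (0.08 log units; within the scatter). In this assay compound 4 is estimated at 24000 nM, expected between 10000 nM and 55000 nM.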

Compound 4, concentration lethal to 50% of the cells: 57500 nM
Estimate against measurement, compound 4: 2.4-fold (0.38 log units) below, and the stated range ends below it.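

In this assay, amino in place of hydrogen on an aromatic carbon gives a 2.9-fold higher number from compound 3 to compound 4 (0.46 log units; beyond the scatter), and the step on the other core cannot be told apart from it: the same change on two cores in this assay, a 1.2-fold higher number (0.08 log units; within the scatter) from compound 1 to compound 2 and a 2.9-fold higher number (0.46 log units; beyond the scatter) from compound 3 to compound 4, 2.4-fold (0.38 log units) apart, within the scatter of two such steps. Going by these compounds alone, the change can therefore be carried between these two cores with no measurable difference in the size of the step, even though only one of the two steps lies beyond the scatter. This rests on two pairs only and does not show that the step would keep its size on any further core.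

Still open, from the compounds shown here alone, is whether a methylamino or a hydroxyl group on the same aromatic carbon would behave like amino. Also open, going by these compounds, is whether the step holds with bromo in place of the chloro group.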